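Compound 3 to compound 4: one group exchanged

A few compounds are considered here, and "the series" means these few. Any claim that something is new, unique, unknown or untested is made for them only; others in the source may bear on it.

Values measured so far in an ADME assay on microsomes from liver (Mus musculus) for metabolic stability, read by LC-MS, with a stated time of 10 min (on this read-out higher numbers stand for a more stable compound and lower numbers for a less stable compound), are these.
Compound 1 `CN(C[C@H]1Cc2c(cccc2N2CCN(C3CC3)CC2)CN1)[C@H]1CCCc2cccnc21` gives 7% in this assay
Compound 2 `CC(C)N1CCN(c2cccc3c2C[C@H](CN(C)[C@H]2CCCc4cccnc42)NC3)CC1` gives 15.1% in this assay
Compound 3 `C[C@@H]1CN(c2cccc3c2C[C@H](CN(C)[C@H]2CCCc4cccnc42)NC3)C[C@H](C)N1C` gives 39.6% in this assay

Of the three, compound 3 stands highest, and its steps to both others lie beyond the scatter. The next structure is compound 4 `CN(C[C@H]1Cc2c(cccc2N2C[C@H]3C[C@@H]2CN3)CN1)[C@H]1CCCc2cccnc21` and it has not yet been measured. The structural change is a group of 7 heavy atoms (5 carbon, 2 nitrogen; 2 five-membered non-aromatic rings with 1 hetero atom each) in place of a group of 9 heavy atoms (7 carbon, 2 nitrogen; one six-membered non-aromatic ring with 2 hetero atoms), on an aromatic carbon and the rest of the molecule stays the same.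

Within the data shown here, three measured steps bear on this change, all at the same aromatic carbon. Exchanging the group on the ring nitrogen gave a number 8.1 percentage points higher from compound 1 to compound 2 (within the scatter) and no more. The 3,4,5-trimethylpiperazin-1-yl group gave a number 24.5 percentage points higher from compound 2 to compound 3 (beyond the scatter) and also a number 32.6 percentage points higher from compound 1 to compound 3 (beyond the scatter) as the largest step. Exchanges at this place can therefore shift the read-out considerably. None of these steps brings in the two five-membered non-aromatic rings, however, so they give no firm direction for this change. The expected result is a number 5.4 percentage points higher from compound 3 to compound 4 (within the scatter) as the central estimate, with no step beyond the scatter expected, although a larger one in either direction remains possible. In this assay compound 4 is estimated at 45% with an expected range from 20% to 72% for a single measurement.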

Compound 4, percent of the compound remaining: 95.9%
Compound 4: middle estimate off by 50.9 percentage points, on the low side; measured number above the stated range.
By their numbers in this assay, from the lowest: compounds 1 and 2 (each within the scatter of the next); then compound 3; then compound 4.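

In this assay, the group with 2 five-membered non-aromatic rings on this aromatic carbon gave a number 56.3 percentage points higher from compound 3 to compound 4 (beyond the scatter), and against the two piperazines with a group on the ring nitrogen it gave a number 80.8 percentage points higher from compound 2 to compound 4 (beyond the scatter) and a number 88.9 percentage points higher from compound 1 to compound 4 (beyond the scatter). Each of these steps is larger than the biggest step among the earlier compounds, a number 32.6 percentage points higher from compound 1 to compound 3 (beyond the scatter), so this position can carry a far greater change in the read-out than exchanges within the piperazine series had shown, and compound 4 stands above all the others by steps beyond the scatter. The change alters the ring system, the heavy-atom count and the hydrogen-bond donor count together, with 1 donor in the entering group and 0 in the group that leaves compound 3, and no measurement at hand explains the result.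

The compounds shown cannot separate these features, so it remains open whether a plain piperazin-1-yl group with hydrogen on its ring nitrogen would give a similar number. From the compounds shown here alone, it is equally open whether a methyl or cyclopropyl group on the free nitrogen of the entering group, or the mirror-image form of that group, would keep it.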